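This account rests on a few compounds, and the source may have more. Where it says the series, first, only, none or still open, it means among the compounds named here.

Working notes on the series. Compound 1 `Nc1cc(N)c2nc(-c3ccccc3)c(Oc3ccc(Cl)c(Cl)c3)nc2c1`, compound 2 `Nc1cc(N)c2nc(-c3ccccc3)c(NCc3ccc(Cl)c(Cl)c3)nc2c1` and compound 3 `COc1ccc(CNc2nc3cc(N)cc(N)c3nc2-c2ccccc2)cc1OC` share one core and differ only in the group hung from the saturated chain carbon bound to a nitrogen on an aromatic ring, or in the atom that joins it. In a functional assay on UO-31 cells (Homo sapiens) for inhibition, read by sulforhodamine B assay, with a stated time of 48 h (on this read-out higher numbers stand for weaker inhibition of growth and lower numbers for stronger inhibition of growth), compound 1 gives only a limit of the assay, < 100000 nM, and no number. In this assay compound 2 likewise gives only a limit, < 100000 nM. In this assay, among the measured compounds shown here, compound 3 gives 45700 nM, the one number in the set. The other two values sit at the limit of < 100000 nM in this assay, at which 2 of the 3 values shown sit. The step that the limit leaves unreadable from compound 2 to compound 3 is unreadable for that reason, so its size is unknown.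

Compound 4 `Nc1cc(N)c2nc(-c3ccccc3)c(NCc3ccc(F)cc3)nc2c1`, not yet measured, differs from compound 3 by 4-fluorophenyl in place of 3,4-dimethoxyphenyl on a saturated chain carbon bound to a nitrogen on an aromatic ring. No readable measured step bears on this change. For compound 4 the step of a 1.1-fold higher number from compound 3 to compound 4 (0.04 log units; within the scatter) is therefore expected, nothing beyond the scatter. Compound 4 is estimated at 50000 nM, within a range of 15000 nM to 100000 nM, with a fair chance that only a limit is reported.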

Compound 4, concentration for total growth inhibition: < 100000 nM
Compound 4: a limit, no number; the forecaster's own chance of this, stated with the estimate: 30%; the middle value is on the limit's open side.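

In this assay, among the compounds shown here, compound 4 gives only a limit, so no step linking compound 4 with compound 1, compound 2 or compound 3 can be read: the limit of < 100000 nM in this assay, at which 3 of the 4 values shown sit. As far as these compounds go, whether 4-fluorophenyl, 3,4-dichlorophenyl and 3,4-dimethoxyphenyl differ at all in this read-out remains open.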